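This account rests on a few compounds, and the source may have more. Where it says the series, first, only, none or still open, it means among the compounds named here.

Measured so far, in an assay on HEK293 cells for inhibition of melanin-concentrating hormone receptor 1 (Homo sapiens), read by radioligand binding; on this read-out lower numbers stand for stronger inhibition and higher numbers for weaker inhibition:
Compound 1 `CN(C)c1nc(N[C@H]2CC[C@@H](NC(=O)c3ccccc3F)CC2)nc2ccccc12` gives 170 nM.
Compound 2 `Cc1cccc(C(=O)N[C@H]2CC[C@@H](Nc3nc(N(C)C)c4ccccc4n3)CC2)c1` gives 4.6 nM.

Compound 2 has the lowest number of the two in this assay; its nearest neighbour is compound 1, at 170 nM. Among the compounds with values here, the one measured step, a 37-fold lower number from compound 1 to compound 2 (1.57 log units; beyond the scatter), changes both the kind and the placing of the group on the ring attached to the carbonyl carbon, and it is large. Compound 3 `CN(C)c1nc(N[C@H]2CC[C@@H](NC(=O)c3cccc(Cl)c3)CC2)nc2ccccc12` keeps the core of compound 2 and differs in one place only: chloro in place of methyl on an aromatic carbon. Within the data shown here, no measured step exchanges a methyl for a chloro on that ring, so the step from compound 1 to compound 2 bears on it only loosely, by showing that the group on this ring matters. With the group exchanged at the same position of the same ring, the expected step in this assay for compound 3 is a 1.1-fold higher number from compound 2 to compound 3 (0.04 log units; within the scatter), that is, none beyond the scatter. Compound 3 is therefore estimated at 5 nM, within a range of 1.5 nM to 16 nM.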

Compound 3, half-maximal inhibitory concentration: 4.5 nM
Compound 3: the middle estimate sits 1.1-fold (0.05 log units) above what was measured; the measured number falls inside the stated range.
By their numbers in this assay, from the lowest: compounds 3 and 2 (each within the scatter of the next); then compound 1.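

In this assay, the step from methyl to chloro is a 1.0-fold lower number from compound 2 to compound 3 (0.01 log units; within the scatter), so at this place, meta to a large group, these two groups of one heavy atom each cannot be told apart. The second step, a 38-fold lower number from compound 1 to compound 3 (1.58 log units; beyond the scatter), is large, which shows that the large step seen earlier with 3-methylphenyl is not tied to the methyl group alone, since 3-chlorophenyl gives a step of the same kind. No measurement here speaks to why methyl and chloro give such close numbers.

Going by these compounds, whether a larger or very different group at this place, such as a methoxy group, an amine or a carboxylic acid, would keep the number this low remains open. A 3-fluorophenyl compound would be needed to separate the effect of the kind of group from that of its placing on the ring.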